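Dimethylphenyl in place of fluorophenyl on the ether oxygen

The source may report more compounds than this note shows. Statements on the series, on what has been measured and on what is new or still open speak of the compounds shown alone.

Compound 2 `CC(Oc1ccccc1F)C(=O)Nc1ccc(OCC(=O)O)c(F)c1` was examined in a functional assay on CHO cells for agonist activity at Free fatty acid receptor 1 (Homo sapiens), read by FLIPR (on this read-out higher numbers stand for an effect only at larger amounts of compound and lower numbers for an effect already at smaller amounts), where compound 2 gives 136 nM. Its closest relative, compound 1 `CC(Oc1ccccc1)C(=O)Nc1ccc(OCC(=O)O)c(F)c1`, gives 135 nM in this assay; the step of a 1.0-fold higher number from compound 1 to compound 2 (0.00 log units; within the scatter) keeps the two within the scatter of each other, so compound 2 sits together with compound 1 rather than apart from it. A further member of the series, compound 3 `COc1ccc(OCC(=O)Nc2ccc(OCC(=O)O)c(F)c2)cc1`, was described, but for compound 3 the entry in this assay reads "not determined" (no result reported), so no number is available for it.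

Compound 4 `Cc1ccc(OC(C)C(=O)Nc2ccc(OCC(=O)O)c(F)c2)cc1C` has not yet been measured. It differs from compound 2 in one place: 3,4-dimethylphenyl in place of 2-fluorophenyl on an oxygen on a saturated carbon. Among the measured compounds shown here, the only measured step that bears on this position is a 1.0-fold higher number from compound 1 to compound 2 (0.00 log units; within the scatter), which lay within the scatter, so the one change seen so far on the ring on that oxygen left the read-out unmoved. On that basis the step is expected to be small, a 1.1-fold lower number from compound 2 to compound 4 (0.05 log units; within the scatter), with no direction beyond the scatter. Compound 4 is therefore estimated to give 120 nM in this assay, within a range from 45 nM to 320 nM.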

Compound 4, half-maximal effective concentration: 133 nM
The estimate for compound 4 lay 1.1-fold (0.04 log units) below the measured number, and the stated range covers the measured number.
By their numbers in this assay, from the lowest: compounds 4, 1 and 2 (each within the scatter of the next).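

Compound 4 extends the picture at this position from a single fluoro on the ring to a different substitution, as 3,4-dimethylphenyl carries two methyl groups and no fluorine, yet the read-out in (this assay) still does not move (a 1.0-fold lower number from compound 2 to compound 4 (0.01 log units; within the scatter)) and (a 1.0-fold lower number from compound 1 to compound 4 (0.01 log units; within the scatter)). The three compounds with numbers, bearing phenyl, 2-fluorophenyl and 3,4-dimethylphenyl on the oxygen, therefore all lie within the scatter of one another, so a change of substitution on this carbon-only ring has so far shifted nothing. Nothing at hand explains why the read-out stays flat here.

Still open, as far as these compounds go, is whether this holds for a ring bearing an amine or a carboxylic acid. From the compounds shown here alone, it is equally open what a pyridine ring or a longer chain would do in place of the ring on that oxygen.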